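This account rests on a few compounds, and the source may have more. Where it says the series, first, only, none or still open, it means among the compounds named here.

Compounds measured so far:
compound 1 `CN1CCC[C@H]1[C@H]1COc2ccc(N)cc2O1` — 180 nM
compound 2 `CN1CCC[C@H]1[C@@H]1COc2cc(N)ccc2O1` — 3500 nM
compound 3 `CN1CCC[C@H]1[C@H]1COc2ccc([N+](=O)[O-])cc2O1` — 2100 nM

In an assay on membranes from HEK293 cells for displacement of a labelled ligand from Neuronal acetylcholine receptor; alpha3/beta4 (Homo sapiens), with a stated time of 5 min (on this read-out higher numbers stand for weaker inhibition and lower numbers for stronger inhibition), compound 1 gives 180 nM, compound 2 gives 3500 nM and compound 3 gives 2100 nM. Compound 2 has the highest of the three numbers; its gap to compound 3 lies within the scatter, while its gap to compound 1 lies beyond it. Compound 1 and compound 2 have the same atoms joined differently, and the difference between the two cores is not broken down here.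

Within the core of compound 1, the change nitro in place of amino on an aromatic carbon gives the step of a 12-fold higher number from compound 1 to compound 3 (1.07 log units; beyond the scatter). The same change, (nitro in place of amino on an aromatic carbon), leads from compound 2 to the not yet measured compound 4 `CN1CCC[C@H]1[C@@H]1COc2cc([N+](=O)[O-])ccc2O1`.

Among the measured compounds shown here, on the core of compound 2 a step of about the same size is expected, an 8.6-fold higher number from compound 2 to compound 4 (0.93 log units; beyond the scatter), because a 12-fold higher number from compound 1 to compound 3 (1.07 log units; beyond the scatter) is the only measured instance of this change. Compound 4 is therefore estimated at 30000 nM, between 8000 nM and 120000 nM.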

Compound 4, inhibition constant: 15000 nM
For compound 4 the middle estimate is 2.0-fold (0.30 log units) above the measured one, within the range that was stated.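

In this assay, nitro in place of amino on the core of compound 2 gives a 4.3-fold higher number from compound 2 to compound 4 (0.63 log units; beyond the scatter), so the number rises on this core as it did on the core of compound 1. The direction of the change carries over between these two cores, but its size does not: the same change on two cores in this assay, a 12-fold higher number (1.07 log units; beyond the scatter) from compound 1 to compound 3 and a 4.3-fold higher number (0.63 log units; beyond the scatter) from compound 2 to compound 4, 2.7-fold (0.43 log units) apart, beyond the scatter of two such steps. Among the compounds shown here, with only two cores, this does not show how the change would behave on any further core, and it assigns the difference in size to no property of either group.

The compounds shown leave open how other groups on this aromatic carbon, such as a methoxy group, an acetamide or a carboxylic acid, would compare with amino and nitro on either core. They also leave open which feature of the two cores, whose atoms are joined differently, goes with the different size of the step.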